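Oxadiazole Replaces Sulfonamide on the Pyridine Ring

This account rests on a few compounds, and the source may have more. Where it says the series, first, only, none or still open, it means among the compounds named here.

Measured compounds:
compound 1 `CC(C)(C)c1ccc(NC(=O)c2ccc(-c3ncccc3F)cc2)cc1` — 1 nM
compound 2 `CC(C)(C)c1ccc(NC(=O)c2ccc(-c3ncccc3NC3CCCC3)cc2)cc1` — 44 nM
compound 3 `CC(C)(C)c1ccc(NC(=O)c2ccc(-c3ncccc3NS(=O)(=O)c3ccccc3)cc2)cc1` — 166 nM

In a functional assay for antagonist activity at transient receptor potential cation channel subfamily V member 1 (Rattus norvegicus) (on this read-out lower numbers stand for stronger inhibition and higher numbers for weaker inhibition), compound 1 gives 1 nM and is the most potent of the three. Compound 3 stands at the other end: its number is the highest of the three, with compound 2 nearest and compound 1 furthest away. Both steps away from the fluoro group were large, a 44-fold higher number from compound 1 to compound 2 (1.64 log units; beyond the scatter) and a 170-fold higher number from compound 1 to compound 3 (2.22 log units; beyond the scatter), while the exchange between the two larger groups was modest, a 3.8-fold higher number from compound 2 to compound 3 (0.58 log units; beyond the scatter).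

Compound 4 `Cc1nnc(-c2cccnc2-c2ccc(C(=O)Nc3ccc(C(C)(C)C)cc3)cc2)o1` has not yet been measured. It differs from compound 3 in one place: 5-methyl-1,3,4-oxadiazol-2-yl in place of (phenylsulfonyl)amino on an aromatic carbon. The measured steps show that the shared core tolerates changes at this aromatic carbon only with a loss against compound 1, but that exchanging one substituent there for another moves the number by a modest amount, as seen from compound 2 to compound 3. Compound 4 is therefore expected to land between compound 3 and compound 1, and the step of a 6.6-fold lower number from compound 3 to compound 4 (0.82 log units; beyond the scatter) is expected to be a lower number, beyond the scatter. The estimate for compound 4 is 25 nM, with a range from 5 nM to 120 nM.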

Compound 4, half-maximal inhibitory concentration: 34 nM
Compound 4: middle estimate off by 1.4-fold (0.13 log units), on the low side, within the range that was stated.
By their numbers in this assay, from the lowest: compound 1; then compounds 4 and 2 (each within the scatter of the next); then compound 3.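

In this assay, a five-membered aromatic ring with 3 hetero atoms and 0 hydrogen-bond donors is accepted on this aromatic carbon, and 5-methyl-1,3,4-oxadiazol-2-yl gives a lower number than (phenylsulfonyl)amino (a 4.9-fold lower number from compound 3 to compound 4 (0.69 log units; beyond the scatter)). Within the data shown here, the same group stands level with cyclopentylamino (a 1.3-fold lower number from compound 2 to compound 4 (0.11 log units; within the scatter)), so this position does not separate these two quite different substituents, and a hydrogen-bond donor on the group is not needed to reach this level, although the set holds only this one group without one among the three larger substituents. Fluoro remains clearly apart from the new group (a 34-fold higher number from compound 1 to compound 4 (1.53 log units; beyond the scatter)), and no measurement shown accounts for any of these steps.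

The compounds shown leave open whether the loss against compound 1 follows the size of the group, which small groups such as chloro, methyl or nitrile on this aromatic carbon could test. They also leave open what the methyl on the 1,3,4-oxadiazole contributes, a question that a hydrogen, an ethyl or an aminomethyl in its place would address.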